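Widening the amine at the end of a propyl chain

The source may hold more compounds than are shown below. What is called first, only, known or untested is meant among the compounds shown, and "the series" means these compounds.

The values in a functional assay on HeLa cells (Homo sapiens) for antiproliferative activity, read by MTT assay, with a stated time of 48 h (a higher number here means a weaker inhibitor, a lower number a stronger inhibitor), are these:

- Compound 1 `CCN(CC)CCCn1c(N)c(-c2nc3ccccc3[nH]2)c2nc(C#N)c(C#N)nc21` gives 3150 nM as its value
- Compound 2 `CN(C)CCn1c(N)c(-c2nc3ccccc3n2C)c2nc(C#N)c(C#N)nc21` stands at > 50000 nM, which is a limit of the assay and not a number
- Compound 3 `CN(C)CCCn1c(N)c(-c2nc3ccccc3n2C)c2nc(C#N)c(C#N)nc21` gives 4320 nM as its value

Compound 3, at 4320 nM, lies within the scatter of compound 1, at 3150 nM, so neither can be ranked over the other. Within the data shown here, the one measured step, an at least 11-fold lower number from compound 2 to compound 3 (1.06 log units; beyond the scatter), was large, but it starts from the limit of > 50000 nM in this assay, at which 1 of the 3 values shown sits, so its true size remains open. That step also concerns the length of the chain, not the group at its end.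

Compound 4 `CCN(CC)CCCn1c(N)c(-c2nc3ccccc3n2C)c2nc(C#N)c(C#N)nc21` differs from compound 3 by one change, (diethylamino in place of dimethylamino on a saturated chain carbon, three bonds along the chain from an aromatic nitrogen), so that 3-(dimethylamino)propyl becomes 3-(diethylamino)propyl. Among the measured compounds shown here, no measured step makes this exchange directly. The nearest guide is compound 1, which already carries 3-(diethylamino)propyl on a core that is not quite the same and gives 3150 nM, within the scatter of compound 3. No step beyond the scatter is therefore expected in this assay, in either direction. The expected change is a 1.2-fold lower number from compound 3 to compound 4 (0.09 log units; within the scatter). Compound 4 is estimated at 3500 nM, with an expected range of 1500 nM to 8500 nM.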

Compound 4, half-maximal inhibitory concentration: 12400 nM
Compound 4: middle estimate off by 3.5-fold (0.55 log units), on the low side, outside the stated range (above it).
By their numbers in this assay, from the lowest: compounds 1 and 3 (each within the scatter of the next); then compound 4. At a limit, above all of these: compound 2.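

In this assay, among these compounds, the group at the end of the propyl chain proves to matter in its own right: a 2.9-fold higher number from compound 3 to compound 4 (0.46 log units; beyond the scatter) is beyond the scatter, whereas the only earlier step concerned the length of the chain. With 3-(diethylamino)propyl held constant, methyl in place of hydrogen on an aromatic nitrogen gives a 3.9-fold higher number from compound 1 to compound 4 (0.60 log units; beyond the scatter) and so also counts. Going by these compounds, the last new step of an at least 4.0-fold lower number from compound 2 to compound 4 (0.60 log units; beyond the scatter) starts from a limit of the assay and not from a number, so its true size stays open: the limit of > 50000 nM in this assay, at which 1 of the 4 values shown sits.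

What the compounds shown leave open is whether the number keeps rising with a still larger amine on the propyl chain, such as dipropylamino, or how a cyclic amine such as piperidine or morpholine would behave there. They also leave open whether dimethylamino on the propyl chain would respond in the same way to hydrogen in place of the methyl on the aromatic nitrogen.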